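A few compounds are considered here, and "the series" means these few. Any claim that something is new, unique, unknown or untested is made for them only; others in the source may bear on it.

Three compounds share one core and differ only in the group carried on a saturated chain carbon bound to an oxygen on an aromatic ring. Compound 1 `COc1cccc(OC)c1OCCNCCOc1ccccc1OCc1ccc(Cl)cc1` carries a 4-chlorophenyl there; in a functional assay on thoracic aorta for antagonist activity at Alpha-1D adrenergic receptor (Rattus norvegicus) (a lower number here means a less potent compound, a higher number a more potent compound, by a factor of ten per unit of this negative logarithm), compound 1 gives 9.11. Compound 2 `COc1ccccc1COc1ccccc1OCCNCCOc1c(OC)cccc1OC` gives 8.86 and compound 3 `COc1cccc(COc2ccccc2OCCNCCOc2c(OC)cccc2OC)c1` gives 9.12. Among these three numbers compound 1 stands second highest; its nearest neighbour is compound 3, and the step of a number 0.01 log units higher from compound 1 to compound 3 (within the scatter) lies within the scatter, while the step of a number 0.25 log units lower from compound 1 to compound 2 (within the scatter) to the furthest compound also lies within the scatter, as does a number 0.26 log units higher from compound 2 to compound 3 (within the scatter).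

Compound 4 `CCOc1ccc(COc2ccccc2OCCNCCOc2c(OC)cccc2OC)cc1` differs from compound 1 in one place: ethoxy in place of chloro on an aromatic carbon. For the measured compounds named here, no measured step exchanges chloro for ethoxy, so the only bearing comes from the three exchanges of the whole aryl group, all of which stayed within the scatter. Since every change tried at this position left the number essentially unmoved, the expected step from compound 1 to compound 4 is a number 0.11 log units lower from compound 1 to compound 4 (within the scatter), which is no step beyond the scatter. Compound 4 is therefore estimated at 9, with a range from 8.5 to 9.5.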

Compound 4, negative logarithm of the antagonist equilibrium constant: 9.11
For compound 4 the middle estimate is 0.11 log units below the measured one, and the stated range covers the measured number.
By their numbers in this assay, from the lowest: compounds 2, 1, 4 and 3 (each within the scatter of the next).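

For the compounds shown here, this is the first direct exchange on the aromatic carbon itself, and in this assay putting ethoxy (3 heavy atoms, 1 hydrogen-bond acceptor) in place of chloro (1 heavy atom, no acceptor) gives no change at the digits printed from compound 1 to compound 4 (within the scatter) and so leaves the number unmoved. Going by these compounds alone, the exchanges of the whole aryl group tell the same story, with a number 0.01 log units lower from compound 3 to compound 4 (within the scatter) and a number 0.25 log units higher from compound 2 to compound 4 (within the scatter) both small, so across these four compounds the position accepts chloro, methoxy at two different places on the ring and ethoxy without any step beyond the scatter, and no compound goes against this. Nothing available explains why these groups give such closely matched numbers.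

The compounds shown leave open whether this tolerance would survive a group of a different kind on the same aromatic carbon, such as an amine or a carboxylic acid, or a longer chain such as hexyloxy. They also leave open whether the same flat picture would hold at any other receptor, since all of these numbers come from a single assay.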